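Stereochemical switch at the chain carbon of compound 2

The source may hold more compounds than are shown below. What is called first, only, known or untested is meant among the compounds shown, and "the series" means these compounds.

Measured compounds:
compound 1, `Cc1ccc(NC(=O)N[C@@H](C)c2ccccc2)cc1`, 100%
compound 2, `CCCCCCCc1ccc(NC(=O)N[C@H](C)c2ccccc2)cc1`, 100%

In an ADME assay on the whole organism with Oryza sativa as the target, tested at 0.1 uM (a higher number here means a weaker effect of the compound at the concentration tested, a lower number a stronger effect), compound 1 gives 100%. Compound 2 carries a heptyl chain where compound 1 carries a methyl group; in this assay compound 2 gives 100%. The two values are level at the digits reported, so no change beyond the usual scatter is seen between compound 1 and compound 2, and neither can be called the more or less active of the pair.

The next compound, compound 3, `CCCCCCCc1ccc(NC(=O)N[C@@H](C)c2ccccc2)cc1`, has not yet been measured in this assay. It is related to compound 2 as follows: the two compounds have the same atoms and bonds and differ only in configuration as drawn: 1 of 1 stereo elements differ; a stereocentre at a saturated chain carbon is drawn R in compound 2 and S in compound 3.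

For the measured compounds named here, no step between two measured compounds that differ in only one place is available, so the size of this step cannot be read from the data. Compound 1, which is drawn with the same configuration at that centre as compound 3, sits at the same level as compound 2, which leaves nothing that would point to a shift either way. Compound 3 is therefore expected to remain level, with an estimated step of no change at the digits printed from compound 2 to compound 3 (within the scatter). In this assay compound 3 is estimated at 100%, within a range from 88% to 100%.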

Compound 3, a percentage reported as activity, at one concentration (the size of the read-out at that concentration, not a potency): 100%
Estimate against measurement, compound 3: no gap at the digits printed, within the range that was stated.
By their numbers in this assay, from the lowest: compounds 1, 2 and 3 (each within the scatter of the next).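

In this assay, the switch from R to S at the saturated chain carbon comes with no change at the digits printed from compound 2 to compound 3 (within the scatter), and this comparison speaks to that stereocentre alone because of one structural fact: the fact that compounds 2 and 3 differ only in the configuration as drawn. With the S configuration held, hexyl in place of hydrogen on a saturated chain carbon bound to an aromatic carbon comes with no change at the digits printed from compound 1 to compound 3 (within the scatter), so the chain change can now be read as a single-place step, which the earlier pair of compound 1 and compound 2 did not allow. Neither change therefore takes the read-out in this assay away from the level of compound 3 at 100%, for this one pair of configurations and this one pair of chain lengths.

On these data alone, whether an amine, a carboxylic acid or a chain longer than heptyl in place of the heptyl chain would depart from this level stays open. Also open is whether the configuration at the chain carbon would count in a compound whose read-out in this assay sits away from this level, since all the compounds shown lie together.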